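This account rests on a few compounds, and the source may have more. Where it says the series, first, only, none or still open, it means among the compounds named here.

Of the compounds shown here, three have been measured in an assay on HEK293 cells for antagonist activity at transient receptor potential M8 protein (Canis lupus familiaris), read by fluorescence and calcium flux, with a stated time of 5 min; on this read-out higher numbers stand for weaker inhibition and lower numbers for stronger inhibition. Compound 1 `O=C(C(Nc1ccccc1)c1ccc(C(F)(F)F)cc1)N1CCCC1c1ccccc1F` gives 30 nM in this assay. Compound 2 `O=C(C(Nc1ccccc1)c1ccc(C(F)(F)F)cc1)N1CCC[C@@H]1c1ccccc1Cl` gives 168 nM in this assay. Compound 3 `O=C(C(Nc1ccccc1F)c1ccc(C(F)(F)F)cc1)N1CCCC1c1cccc(F)c1` gives 9 nM in this assay. Compound 3 thus stands lowest of the three numbers: the nearest number is that of compound 1, higher by a margin beyond the usual scatter, and the furthest is that of compound 2, higher by a much wider margin, so compound 3 is the strongest inhibitor among the measured set.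

Compound 4 `O=C(C(Nc1ccccc1F)c1ccc(C(F)(F)F)cc1)N1CCCC1c1ccncc1` has not yet been measured. It differs from compound 3 in one place: pyridin-4-yl in place of 3-fluorophenyl on a saturated ring carbon. Among the measured compounds shown here, no measured pair shows this same exchange, so there is no direct precedent for its size or direction. Among the three measured compounds, the group on this saturated ring carbon is always a substituted phenyl, and every change there is accompanied by other changes, so the effect of this single exchange cannot be read off. The expectation for the step from compound 3 to compound 4 in this assay is a moderate loss of potency, a 3.3-fold higher number from compound 3 to compound 4 (0.52 log units; beyond the scatter), a step somewhat beyond the scatter. Compound 4 is accordingly estimated at 30 nM in this assay, with a range from 8 nM to 150 nM.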

Compound 4, half-maximal inhibitory concentration: 19 nM
Compound 4: middle estimate off by 1.6-fold (0.20 log units), on the high side; measured number inside the range.
By their numbers in this assay, from the lowest: compound 3; then compounds 4 and 1 (each within the scatter of the next); then compound 2.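

In this assay, among the compounds shown here, putting pyridin-4-yl in place of 3-fluorophenyl on the saturated ring carbon gives a 2.1-fold higher number from compound 3 to compound 4 (0.32 log units; beyond the scatter), a modest step and the first change at this position that can be read on its own. The earlier compounds shown here carried only substituted phenyl groups here, whereas compound 4 reaches 19 nM with a six-membered aromatic ring that contains one hetero atom and has one hydrogen-bond acceptor, so potency in the nanomolar range at this position does not depend on a carbon-only ring or on a fluorine. Nothing measured here accounts for the size of this step, and its origin remains unknown.

As far as these compounds go, it remains open whether the place of the ring nitrogen matters, which pyridin-3-yl or pyridin-2-yl could test, and whether an aromatic ring is needed here at all, which cyclohexyl or piperidin-4-yl could test. From the compounds shown here alone, it is also open whether the same exchange would give a step of similar size on the core of compound 1, where the other parts of the molecule differ.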